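Adding a bromo group to compound 2

The compounds below may be only part of what the source reports. "The series", "measured", "known", "first", "only" and "open" are said of these compounds alone.

In a functional assay on PC-3 cells (Homo sapiens) for cytotoxicity (a higher number here means that more compound is needed for the effect, a lower number that less compound is needed), compound 1 (`COC1=C(C)C(=O)/C(=C(O)/C=C/c2ccccc2OC)C(=O)C1(C)C`) gives 15.6 ug/mL while compound 2 (`CCCC1=C(OC)C(CCC)(CCC)C(=O)/C(=C(O)\C=C\c2ccccc2)C1=O`) gives 3.3 ug/mL as its value. Compound 2 thus holds the lower of the two numbers, so less of it is needed for the effect, and the gap between the two lies beyond the usual scatter of repeated measurements. These two compounds differ in more than one place, so their gap cannot be pinned on any single group.

Compound 3 (`CCCC1=C(OC)C(CCC)(CCC)C(=O)/C(=C(O)\C=C\c2ccc(Br)cc2)C1=O`) has not been measured yet. It differs from compound 2 in one place, with bromo in place of hydrogen on an aromatic carbon para to a large group, which turns phenyl into 4-bromophenyl. For the measured compounds named here, no measured pair shows this change alone, so the data give no direct guide to its size. In this assay the expected result is no step beyond the scatter, with no firm direction. The estimate is a 1.1-fold lower number from compound 2 to compound 3 (0.04 log units; within the scatter) as the expected step. For compound 3 the expected value is 3 ug/mL with an estimated range from 1.2 ug/mL to 7.5 ug/mL as the likely span.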

Compound 3, concentration for half-maximal effect: 2.3 ug/mL
The estimate for compound 3 lay 1.3-fold (0.12 log units) above the measured number; measured number inside the range.
By their numbers in this assay, from the lowest: compounds 3 and 2 (each within the scatter of the next); then compound 1.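

For the compounds shown here, this is the first change in a single place that can be read in this assay: bromo takes the place of hydrogen on an aromatic carbon, para to a large group, which turns phenyl into 4-bromophenyl and gives a 1.4-fold lower number from compound 2 to compound 3 (0.16 log units; within the scatter). Compounds 2 and 3 therefore cannot be told apart in this read-out, so adding this one bromine atom at this position, on this core, brings neither a clear gain nor a clear loss. No measurement is available here that would explain why the number holds steady across this change.

Going by these compounds, it remains open whether this tolerance belongs to bromo alone or extends to other groups at the same place, such as an amine or a carboxylic acid, which differ from bromo far more than a second halogen such as chloro would. On these data alone, it is also open whether bromo would leave the number just as steady on a different carbon of the same aromatic ring, or on the core of compound 1.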